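Hydrazone series on PC-3: from compound 2 to compound 4

The source may report more compounds than this note shows. Statements on the series, on what has been measured and on what is new or still open speak of the compounds shown alone.

Three compounds of the shared core carry a hydrazone that differs only in the aryl group on the carbon with a double bond to nitrogen. In a functional assay on PC-3 cells (Homo sapiens) for antiproliferative activity, read by MTT assay (a lower number here means a stronger inhibitor, a higher number a weaker inhibitor), compound 1 `Cn1c(=O)c(=O)n(C2CCCC2)c2nc(N/N=C/c3ccccc3)ncc21` gives 48200 nM. Compound 2 `Cn1c(=O)c(=O)n(C2CCCC2)c2nc(N/N=C/c3ccc(F)c(Cl)c3)ncc21` gives 8550 nM, and compound 3 `Cn1c(=O)c(=O)n(C2CCCC2)c2nc(N/N=C/c3cccs3)ncc21` gives 75600 nM. Compound 2 stands lowest of the three; its steps to both others are beyond the scatter, a 5.6-fold lower number from compound 1 to compound 2 (0.75 log units; beyond the scatter) and an 8.8-fold higher number from compound 2 to compound 3 (0.95 log units; beyond the scatter), while a 1.6-fold higher number from compound 1 to compound 3 (0.20 log units; within the scatter).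

The next compound, compound 4 `CSc1ccc(/C=N/Nc2ncc3c(n2)n(C2CCCC2)c(=O)c(=O)n3C)cc1`, is not yet measured. Its change from compound 2 is 4-(methylsulfanyl)phenyl in place of 3-chloro-4-fluorophenyl on a carbon with a double bond to nitrogen.

Among the measured compounds shown here, no measured step places a 4-(methylsulfanyl)phenyl on this carbon, so the bearing of the recorded steps is indirect. Removing the 3-chloro-4-fluorophenyl has twice coincided with a higher number, and the unsubstituted phenyl of compound 1 sits well above compound 2. For the measured compounds named here, the expectation for compound 4 is therefore a move back toward compound 1, a 2.3-fold higher number from compound 2 to compound 4 (0.37 log units; beyond the scatter), modest in size and with wide uncertainty, since a single methylsulfanyl group has no precedent here. Compound 4 is expected to give 20000 nM in this assay, within 6000 nM to 60000 nM.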

Compound 4, half-maximal inhibitory concentration: 21000 nM
Beside the measured number, compound 4's estimate is 1.1-fold (0.02 log units) below it; the measured number falls inside the stated range.
By their numbers in this assay, from the lowest: compound 2; then compound 4; then compounds 1 and 3 (each within the scatter of the next).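

In this assay, among the compounds shown here, methylsulfanyl in place of hydrogen on an aromatic carbon is the first substitution of the phenyl of compound 1 seen to lower the number without chlorine or fluorine (a 2.3-fold lower number from compound 1 to compound 4 (0.36 log units; beyond the scatter)), so at this carbon with a double bond to nitrogen, the gain does not depend on those two halogens. That gain is only partial, as 4-(methylsulfanyl)phenyl in place of 3-chloro-4-fluorophenyl still raises the number (a 2.5-fold higher number from compound 2 to compound 4 (0.39 log units; beyond the scatter)), although both groups carry 8 heavy atoms, so that count alone does not set the number across this pair. The substituted phenyl of compound 4 also stands clear of the thiophen-2-yl (a 3.6-fold lower number from compound 3 to compound 4 (0.56 log units; beyond the scatter)), which places compound 4 in an intermediate position in the series, with compound 2 still the lowest.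

No measurement at hand accounts for these differences. The compounds shown leave open whether chlorine or fluorine carries the lower number of compound 2, and how 4-methoxyphenyl or 4-(dimethylamino)phenyl would compare with 4-(methylsulfanyl)phenyl on this carbon.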